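Trimming a branched side chain on a thiazolidine core

The source may hold more compounds than are shown below. What is called first, only, known or untested is meant among the compounds shown, and "the series" means these compounds.

Measured compounds in a functional assay on Huh-7 cells (Homo sapiens) for inhibition, read by sulforhodamine B assay; on this read-out lower numbers stand for stronger inhibition and higher numbers for weaker inhibition: compound 1 `C#CC(=O)N1C(C(C)CCC)SC[C@@H]1C(=O)OCC` gives 600 nM; compound 2 `C#CC(=O)N1C(c2ccccc2)SC[C@@H]1C(=O)OCC` gives 5300 nM; compound 3 `C#CC(=O)N1C(CC(C)CC(C)(C)C)SC[C@@H]1C(=O)OCC` gives 1600 nM.

Compound 3 stands second highest of the three, between compound 1 and compound 2. Compound 4 `C#CC(=O)N1C(CCCC)SC[C@@H]1C(=O)OCC` differs from it by propyl in place of 1,3,3-trimethylbutyl on a saturated chain carbon bound to a saturated ring carbon. Going by the values given here, no measured step matches this change directly. Among the compounds with values here, the only step on a single change, an 8.8-fold higher number from compound 1 to compound 2 (0.95 log units; beyond the scatter), concerns a ring replacing a chain. Compound 1 and compound 3 differ by chain size, and compound 1, with the smaller 1-methylbutyl, shows the lower number. A smaller chain is therefore expected to bring a modest lowering, a 2.0-fold lower number from compound 3 to compound 4 (0.30 log units; within the scatter). Compound 4 is estimated at 800 nM, within 300 nM to 2000 nM.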

Compound 4, half-maximal inhibitory concentration: 500 nM
For compound 4 the middle estimate is 1.6-fold (0.20 log units) above the measured one; low and high end bracket the measured number.
By their numbers in this assay, from the lowest: compounds 4 and 1 (each within the scatter of the next); then compound 3; then compound 2.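

Shortening the chain in this assay matters here: propyl in place of 1,3,3-trimethylbutyl on this saturated chain carbon gives a step beyond the scatter (a 3.2-fold lower number from compound 3 to compound 4 (0.51 log units; beyond the scatter)). Butyl in place of phenyl on the saturated ring carbon also separates a chain clearly from a ring (an 11-fold lower number from compound 2 to compound 4 (1.03 log units; beyond the scatter)). Hydrogen in place of methyl removes the branch of compound 1 with no change beyond the scatter (a 1.2-fold lower number from compound 1 to compound 4 (0.08 log units; within the scatter)).

On these data alone, how an unbranched hexyl chain, or an amine or carboxylic acid at the chain end, would fare remains open. No evidence is available to explain these differences.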